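Amine swap at the shared core: notes toward compound 4

The compounds below may be only part of what the source reports. "The series", "measured", "known", "first", "only" and "open" are said of these compounds alone.

The compounds share one core and differ in the amine on it. Compound 1 `CN(C)c1nc(/C=C/c2ccccc2)nc2ccsc12` carries dimethylamino, compound 2 `CNc1nc(/C=C/c2cc(OC)c(OC)c(OC)c2)nc2ccsc12` methylamino, compound 3 `COc1cc(/C=C/c2nc(N3CCCC3)c3sccc3n2)cc(OC)c1OC` pyrrolidin-1-yl. In a functional assay on L02 cells (Homo sapiens) for inhibition, read by Griess assay, with stated times of 1 h and 24 h (on this read-out higher numbers stand for weaker inhibition and lower numbers for stronger inhibition), compound 1 returns only a limit of the assay, > 1000000 nM. Compound 2 likewise returns only a limit, > 1000000 nM. Among the measured compounds shown here, compound 3 gives 681000 nM in this assay, and so stands as the only member with a number. Compound 1 and compound 2 both sit at a limit of the assay, as the limit of > 1000000 nM in this assay, at which 2 of the 3 values shown sit, records. For the measured compounds named here, the single measured step at this position, an at least 1.4-fold lower number from compound 2 to compound 3 (0.16 log units; that floor lies within the scatter), is a floor rather than a size, and that floor lies within the scatter.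

Compound 4 `COc1cc(/C=C/c2nc(Nc3ccc(C)cc3)c3sccc3n2)cc(OC)c1OC` is the unmeasured member. The change is (4-methylphenyl)amino in place of pyrrolidin-1-yl on an aromatic carbon. Going by the values given here, only that one measured step bears on it, and it gives no direction beyond the scatter, so no step beyond the scatter is expected in this assay for compound 4. Compound 4 is therefore estimated at 600000 nM, within 150000 nM to 2000000 nM. The expected step amounts to a 1.1-fold lower number from compound 3 to compound 4 (0.05 log units; within the scatter).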

Compound 4, half-maximal inhibitory concentration: < 40000 nM
Compound 4 ended at the assay's limit; the forecaster's own chance of this, stated with the estimate: 35%; middle value at least 15-fold (1.17 log units) away from the limit.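

In this assay the position proves responsive: (4-methylphenyl)amino in place of pyrrolidin-1-yl gives an at least 17-fold lower number from compound 3 to compound 4 (1.23 log units; beyond the scatter) on this aromatic carbon, whereas the earlier step here left only a floor within the scatter. Replacing the methyl on the nitrogen with 4-methylphenyl gives an at least 25-fold lower number from compound 2 to compound 4 (1.39 log units; beyond the scatter) in the same read-out, so a large step also appears when the group on the nitrogen changes and the nitrogen keeps its hydrogen. Both are floors rather than sizes, as compound 4 returns a limit of the assay, not a number: the limit of < 40000 nM in this assay, at which 1 of the 4 values shown sits.

From the compounds shown here alone, how far compound 4 lies past that limit, and so the true size of both steps, remains open. Also open, going by these compounds, is whether the aromatic ring alone accounts for the step, or whether its methyl contributes, which phenylamino or benzylamino at this position would help to separate.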